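The source may hold more compounds than are shown below. What is called first, only, known or untested is meant among the compounds shown, and "the series" means these compounds.

Measured in a functional assay on HepG2 cells (Homo sapiens) for antiproliferative activity, read by MTT assay, with a stated time of 72 h; a lower number here means a stronger inhibitor, a higher number a weaker inhibitor:
- compound 1 `COc1ncc(-c2ccc3c(c2)N(c2ccc(C)cc2)C(=O)CO3)cc1NS(=O)(=O)c1ccc(F)cc1`: 28300 nM
- compound 2 `COc1ncc(-c2ccc3c(c2)NC(=O)CO3)cc1NS(=O)(=O)c1ccc(F)cc1`: 6590 nM
- compound 3 `COc1ncc(-c2ccc3c(c2)N(C2CCCCC2)C(=O)CO3)cc1NS(=O)(=O)c1ccc(F)cc1`: > 40000 nM

The entry for compound 3 is only a limit of the assay, not a number. Compound 4 `COc1ncc(-c2ccc3c(c2)N(C2CC2)C(=O)CO3)cc1NS(=O)(=O)c1ccc(F)cc1` carries cyclopropyl in place of cyclohexyl on an amide-type nitrogen in a ring. Among the measured compounds shown here, two measured steps bear on this change: hydrogen in place of 4-methylphenyl gave a 4.3-fold lower number from compound 1 to compound 2 (0.63 log units; beyond the scatter), and cyclohexyl in place of hydrogen gave an at least 6.0-fold higher number from compound 2 to compound 3 (0.78 log units; beyond the scatter). Cyclopropyl is the smaller group by count, so a modest move to a lower number is expected in this assay. The expected step is an at least 2.5-fold lower number from compound 3 to compound 4 (0.39 log units; beyond the scatter). Compound 4 is estimated at 16000 nM, with an expected range from 7000 nM to 40000 nM.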

Compound 4, half-maximal inhibitory concentration: 14400 nM
The estimate for compound 4 lay 1.1-fold (0.05 log units) above the measured number, within the range that was stated.
By their numbers in this assay, from the lowest: compound 2; then compounds 4 and 1 (each within the scatter of the next). At a limit, above all of these: compound 3.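

Replacing cyclohexyl with cyclopropyl on the amide-type nitrogen turns a limit into a real number, with an at least 2.7-fold lower number from compound 3 to compound 4 (0.44 log units; beyond the scatter). That size is only a floor, because the entry for compound 3 is a limit: the limit of > 40000 nM in this assay, at which 1 of the 4 values shown sits. Cyclopropyl still does not match the bare nitrogen, with a 2.2-fold higher number from compound 2 to compound 4 (0.34 log units; beyond the scatter), and it cannot be told apart from 4-methylphenyl, with a 2.0-fold lower number from compound 1 to compound 4 (0.29 log units; within the scatter).

The compounds shown leave open whether any group on this nitrogen can beat the hydrogen of compound 2. A propyl chain or a chain ending in an amine would help to show whether the ring itself matters.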